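A few compounds are considered here, and "the series" means these few. Any claim that something is new, unique, unknown or untested is made for them only; others in the source may bear on it.

Compound 1 `CCOc1ccc(Cl)cc1-c1nc(N)nc(Nc2ccc(Cl)cc2)n1`: 140 nM; 260 nM (2 entries)
Compound 2 `COc1ccc(Cl)cc1-c1cc(N)nc(Nc2ccc(C=O)cc2)c1`: 260 nM
Compound 3 `CCOc1ccc(Cl)cc1-c1cc(N)nc(Nc2ccc(Cl)cc2)c1`: 50 nM

In an assay on Sf9 cells for inhibition of 1-acyl-sn-glycerol-3-phosphate acyltransferase beta (Homo sapiens) (on this read-out higher numbers stand for weaker inhibition and lower numbers for stronger inhibition), compound 3 gives 50 nM, the lowest of the two single numbers in this set. Its nearest neighbour, compound 2, gives 260 nM, a gap beyond the usual scatter. Compound 1 does not stand as a single number here, since the several entries of compound 1 in this assay, 140 nM; 260 nM (2 entries) show two entries for it.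

Compound 4 `CCOc1ccc(Cl)cc1-c1cc(N)nc(Nc2ccc(C=O)cc2)c1` differs from compound 3 in one place: formyl in place of chloro on an aromatic carbon. Among the measured compounds shown here, no two measured compounds differ in this one place alone, so no measured step tells what this change does. Compound 2, which carries the formyl group, and compound 3, which carries the chloro, also differ in a second place, so their two values give only a loose hint, and that hint points toward a weaker number for the formyl compound.

On that basis the step from compound 3 to compound 4 in this assay is expected to be a modest loss, a 2.6-fold higher number from compound 3 to compound 4 (0.41 log units; beyond the scatter), possibly no larger than the scatter. Compound 4 is therefore estimated at 130 nM, with a range from 45 nM to 400 nM.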

Compound 4, half-maximal inhibitory concentration: 50 nM
Estimate against measurement, compound 4: 2.6-fold (0.41 log units) above; low and high end bracket the measured number.
By their numbers in this assay, from the lowest: compounds 3 and 4 (each within the scatter of the next); then compound 2.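

In this assay, putting formyl in place of chloro on the aromatic carbon para to a large group gives no change at the digits printed from compound 3 to compound 4 (within the scatter), so this read-out does not separate the 4-chlorophenyl from the 4-formylphenyl when the rest of the structure is the same. Among the compounds shown here, the formyl group is therefore tolerated at this place, and the earlier compounds could not show this because none of them formed a one-place pair. With formyl held in place, the methyl in place of hydrogen on the saturated chain carbon bound to an oxygen on an aromatic ring gives a 5.2-fold lower number from compound 2 to compound 4 (0.72 log units; beyond the scatter), so for this pair the number moves with the change at the chain. No measurement shown here gives a reason for either step.

As far as these compounds go, what an amine or a carboxylic acid would do on the same aromatic carbon remains open, as does whether a longer chain on the oxygen would lower the number further. From the compounds shown here alone, it is also open whether formyl and chloro would stay level on the core of compound 1, which differs from the core shared by the other compounds.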